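The compounds below may be only part of what the source reports. "The series", "measured", "known", "first", "only" and "open" are said of these compounds alone.

In an ADME assay (liver) for metabolic stability, with Liver microsome (Rattus norvegicus) as the target, using microsomes and NADPH, with a stated time of 30 min, tested at 1 uM (a higher number here means faster removal of the compound, a lower number slower removal), three compounds share one core and differ only in one aromatic group. Compound 1 `CC(C)n1cc(-c2cc(C(O)(C(F)(F)F)C(F)(F)F)cnc2N2CCN(S(=O)(=O)c3ccc(N)nc3)CC2)cn1` gives 198 mL.min-1.g-1 and stands apart from the other two. Compound 2 `Nc1ccc(S(=O)(=O)N2CCN(c3ncc(C(O)(C(F)(F)F)C(F)(F)F)cc3-c3ccoc3)CC2)cn1` gives 57 mL.min-1.g-1 and compound 3 `Nc1ccc(S(=O)(=O)N2CCN(c3ncc(C(O)(C(F)(F)F)C(F)(F)F)cc3-c3ccncc3)CC2)cn1` gives 31 mL.min-1.g-1 in the same test system, and with a 1.8-fold lower number from compound 2 to compound 3 (0.26 log units; within the scatter) between them the two stand level. Compound 3 therefore shares the low end of the series, and the gap to the top is a 6.4-fold lower number from compound 1 to compound 3 (0.81 log units; beyond the scatter) while the matching gap for the other low compound is a 3.5-fold lower number from compound 1 to compound 2 (0.54 log units; beyond the scatter) on the same scale.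

Compound 4 `COc1cncc(-c2cc(C(O)(C(F)(F)F)C(F)(F)F)cnc2N2CCN(S(=O)(=O)c3ccc(N)nc3)CC2)c1` keeps the core and changes that same aromatic group, with 5-methoxypyridin-3-yl in place of pyridin-4-yl, as counted in 5-methoxypyridin-3-yl in place of pyridin-4-yl on an aromatic carbon for this swap. Among the measured compounds shown here, these three steps are the only guide, and no measured compound carries a methoxy group. Compound 3 at 31 mL.min-1.g-1 is the nearest reference since it also holds a pyridinyl group. For the measured compounds named here, compound 1 at 198 mL.min-1.g-1 is the only measured compound whose aromatic group bears a substituent of its own, so a small rise is expected rather than a fall. The expected change is an estimated 1.6-fold higher number from compound 3 to compound 4 (0.21 log units; within the scatter) in size, and it may not clear the scatter. For compound 4 the estimated value is 50 mL.min-1.g-1 and the expected range runs from 25 mL.min-1.g-1 to 105 mL.min-1.g-1 in this estimate.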

Compound 4, intrinsic clearance in microsomes: 58 mL.min-1.g-1
Beside the measured number, compound 4's estimate is 1.2-fold (0.06 log units) below it; low and high end bracket the measured number.
By their numbers in this assay, from the lowest: compounds 3, 2 and 4 (each within the scatter of the next); then compound 1.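

In this assay, the aromatic carbon ortho to a large group holds 5-methoxypyridin-3-yl, a six-membered aromatic ring with a substituent of its own, and compound 4 stands level with both earlier low compounds (a 1.9-fold higher number from compound 3 to compound 4 (0.27 log units; within the scatter); a 1.0-fold higher number from compound 2 to compound 4 (0.01 log units; within the scatter)). Among the compounds shown here, until now, the only aromatic group with its own substituent was the 1-isopropyl-1H-pyrazol-4-yl of compound 1, yet compound 4 stays clearly apart from it (a 3.4-fold lower number from compound 1 to compound 4 (0.53 log units; beyond the scatter)), so a substituent on this group does not by itself go with the high number seen for compound 1. No measurement shown here gives a reason for these numbers.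

The compounds shown leave open whether the high number of compound 1 belongs to its isopropyl chain or to the pyrazole ring, a question that 1-methyl-1H-pyrazol-4-yl or an unsubstituted pyrazol-4-yl group at this position would address. They also leave open whether the methoxy group can be exchanged for an amine, a nitrile or a longer ether chain on the same pyridine ring while the number stays level with compound 4.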